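The source may report more compounds than this note shows. Statements on the series, on what has been measured and on what is new or still open speak of the compounds shown alone.

Of the compounds shown here, three on a shared core have been measured in a functional assay on ileum (Cavia porcellus) for inhibition of cysteinyl leukotriene receptor (Homo sapiens); on this read-out lower numbers stand for lower potency and higher numbers for higher potency (the scale is a negative logarithm). Compound 1 `CCCc1c(OCCCCCCCCC(=O)O)ccc(C(C)=O)c1O` gives 5.8 in this assay, and compound 2 `CCCc1c(OCCCCC(=O)O)ccc(C(C)=O)c1O` gives 5.8. Among the measured compounds shown here, the only single-site step among them, no change at the digits printed from compound 1 to compound 2 (within the scatter), shortens the acid-bearing chain without moving the number. Compound 3 `CCCc1c(OCCCCCC(=O)O)ccc(C(=O)CC)c1O` gives 6.1, the top number of the three, yet its gaps to compound 1 and to compound 2 are each within the usual scatter, so no ranking follows from these values.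

Compound 4 `CCCc1c(OCCCCCC(=O)O)ccc(C(C)=O)c1O` is the next compound. The change from compound 3 is hydrogen in place of methyl on a saturated chain carbon bound to a carbonyl carbon, cut one bond further out a propanoyl becoming an acetyl. For the measured compounds named here, no measured step touches this position: the step from compound 1 to compound 2 concerns the acid chain alone, and compound 3 differs from compound 1 and from compound 2 in two places at once, so their values only show that the three numbers sit close together. With no directional evidence, the expected step of a number 0.20 log units lower from compound 3 to compound 4 (within the scatter) is none beyond the scatter. The estimate for compound 4 in this assay is therefore 5.9, with a range from 5.5 to 6.3.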

Compound 4, negative logarithm of the antagonist equilibrium constant: 6
Compound 4: the middle estimate sits 0.10 log units below what was measured; the measured number falls inside the stated range.
By their numbers in this assay, from the lowest: compounds 1, 2, 4 and 3 (each within the scatter of the next).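

In this assay, among the compounds shown here, the change from propanoyl to acetyl gives a number 0.10 log units lower from compound 3 to compound 4 (within the scatter) and is the first direct reading of this position, so on this acid chain the methyl that leaves carries no step beyond the scatter. The same result adds two readings on the acid chain with the acetyl kept, a number 0.20 log units higher from compound 2 to compound 4 (within the scatter) and a number 0.20 log units higher from compound 1 to compound 4 (within the scatter) and, together with the earlier step between compound 1 and compound 2, these place the three acetyl compounds within the scatter of one another, with no dependence on chain length visible across the lengths shown. No measurement on these compounds offers an explanation for these small steps.

The compounds shown leave open whether a butanoyl group or a benzoyl group on the same carbonyl position would stay as close to these numbers as propanoyl and acetyl do, and whether the step from propanoyl to acetyl reads the same on the other acid chains. They also leave open what happens to the number when a tetrazole or an amide stands in place of the carboxylic acid.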